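The source may hold more compounds than are shown below. What is called first, only, known or untested is meant among the compounds shown, and "the series" means these compounds.

Measured compounds:
- compound 1 `COc1ccc(Cn2cc(CSC(=S)N3CCN(C(=O)OCc4ccccc4)CC3)nn2)cc1` — 23800 nM in a functional assay on MGC-803 cells (Homo sapiens) for inhibition, read by MTT assay, with a stated time of 72 h; on this read-out lower numbers stand for stronger inhibition and higher numbers for weaker inhibition
- compound 2 `Cc1ccc(Cn2cc(CSC(=S)N3CCN(C(=O)OCc4ccccc4)CC3)nn2)cc1` — 9370 nM
- compound 3 `O=C(OCc1ccccc1)N1CCN(C(=S)SCc2cn(Cc3ccc(F)cc3)nn2)CC1` — 17600 nM

Compound 2 has the lowest of the three numbers. Its separation from compound 1 is a 2.5-fold lower number from compound 1 to compound 2 (0.40 log units; beyond the scatter), whereas compound 2 and compound 3 are separated by a 1.9-fold higher number from compound 2 to compound 3 (0.27 log units; within the scatter), so only the first of these differences counts as a real one.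

Compound 4 `Cc1ccc(Cn2cc(CSC(=S)N3CCNCC3)nn2)cc1` is related to compound 2 by one change: hydrogen in place of benzyloxycarbonyl on an amine nitrogen in a ring. None of the three measured steps bears on this position; each of them concerns a small substituent on an aromatic carbon, and all three were at most modest, as a 2.5-fold lower number from compound 1 to compound 2 (0.40 log units; beyond the scatter) and a 1.4-fold lower number from compound 1 to compound 3 (0.13 log units; within the scatter) show. Removing a whole benzyloxycarbonyl group is a larger alteration than any of them, and the data give no direct guide to its effect. Without such a guide the number is expected to move upward rather than stay put, but with wide uncertainty. Compound 4 is therefore expected to show a 2.7-fold higher number from compound 2 to compound 4 (0.43 log units; beyond the scatter). For compound 4 the estimated value is 25000 nM, with a range from 6000 nM to 100000 nM.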

Compound 4, half-maximal inhibitory concentration: 64300 nM
The estimate for compound 4 lay 2.6-fold (0.41 log units) below the measured number; low and high end bracket the measured number.
By their numbers in this assay, from the lowest: compounds 2, 3 and 1 (each within the scatter of the next, the first and the last beyond it); then compound 4.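

In this assay, replacing benzyloxycarbonyl with hydrogen on the ring nitrogen gives a 6.9-fold higher number from compound 2 to compound 4 (0.84 log units; beyond the scatter) and is the largest step seen so far. The ring nitrogen therefore matters more to this number than the small aromatic substituents compared among compound 1, compound 2 and compound 3, and in this pair, keeping the benzyloxycarbonyl group goes with stronger inhibition. Nothing measured here explains why the number changes at this position.

From the compounds shown here alone, it remains open which part of the benzyloxycarbonyl group matters, and whether a plain benzyl or a small acetyl group on the same nitrogen would keep the lower number. Going by these compounds alone, this change has also been seen only with the methyl-bearing compound, so its size with methoxy or fluoro on the aromatic ring remains unknown.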